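The source may report more compounds than this note shows. Statements on the series, on what has been measured and on what is new or still open speak of the compounds shown alone.

Compound 3 `CN(C)S(=O)(=O)c1ccc2c(c1)C(n1ccccc1=O)=CC(C)(C)O2` gives the lowest of the three numbers in a functional assay on the whole organism (trachea) with Rattus norvegicus as the target (on this read-out lower numbers stand for smaller maximal responses and higher numbers for larger maximal responses), with a value of 74.1%. Compound 2 `CC1(C)C=C(n2ccccc2=O)c2cc(S(=O)(=O)NCc3ccccc3)ccc2O1` gives 77.5%, and compound 1 `CC(C)NS(=O)(=O)c1ccc2c(c1)C(n1ccccc1=O)=CC(C)(C)O2` gives 94.8%. The step of a number 20.7 percentage points lower from compound 1 to compound 3 (beyond the scatter) lies beyond the scatter, whereas a number 3.4 percentage points lower from compound 2 to compound 3 (within the scatter) does not, so compound 3 and compound 2 cannot be ordered against each other. Compound 4 `CC1(C)C=C(n2ccccc2=O)c2cc(S(=O)(=O)c3ccccc3)ccc2O1` differs from compound 3 in one place: phenyl in place of dimethylamino on a sulfonyl sulfur. The two steps that touch the same sulfonyl sulfur, a number 20.7 percentage points lower from compound 1 to compound 3 (beyond the scatter) and a number 3.4 percentage points lower from compound 2 to compound 3 (within the scatter), were modest or within the scatter, and the step of a number 17.3 percentage points lower from compound 1 to compound 2 (beyond the scatter) concerns the sulfonamide nitrogen that compound 4 no longer carries. For the measured compounds named here, no measured step removes the nitrogen altogether, so the expected change is small: a number 1.9 percentage points higher from compound 3 to compound 4 (within the scatter) is the estimated step in this assay. Compound 4 is therefore expected to give about 76%, within a range from 58% to 94%.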

Compound 4, largest response reached (Emax), in percent of the reference or control that the assay uses: 88.1%
Estimate against measurement, compound 4: 12.1 percentage points below; low and high end bracket the measured number.
By their numbers in this assay, from the lowest: compounds 3 and 2 (each within the scatter of the next); then compounds 4 and 1 (each within the scatter of the next).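

In this assay a sulfonyl sulfur with no nitrogen on it still gives a large maximal response: phenyl yields a number 14 percentage points higher from compound 3 to compound 4 (beyond the scatter) and a number 10.6 percentage points higher from compound 2 to compound 4 (beyond the scatter) and stays level with isopropylamino (a number 6.7 percentage points lower from compound 1 to compound 4 (within the scatter)). The sulfonamide nitrogen is therefore not required at this place, and it is dimethylamino and benzylamino, not phenyl, that sit at the low end of these four compounds. Nothing measured here bears on why. Going by these compounds, it remains open whether a methyl group or a pyridyl ring on the sulfonyl sulfur would match phenyl.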